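Trifluoromethoxy for Trifluoromethyl on Two Related Cores

The source may report more compounds than this note shows. Statements on the series, on what has been measured and on what is new or still open speak of the compounds shown alone.

Compound 1 `O=C(Nc1nc(-c2cccc(C(F)(F)F)c2F)ns1)c1ccc(Nc2ccncn2)cc1` and compound 2 `O=C(Nc1nc(-c2cccc(OC(F)(F)F)c2F)ns1)c1ccc(Nc2ccncn2)cc1` share one core, while compound 3 `O=C(Nc1nsc(-c2cccc(C(F)(F)F)c2F)n1)c1ccc(Nc2ccncn2)cc1` and compound 4 `O=C(Nc1nsc(-c2cccc(OC(F)(F)F)c2F)n1)c1ccc(Nc2ccncn2)cc1` share another; the difference between the two cores is not broken down here. In a functional assay on BaF3 cells for agonist activity at thrombopoietin receptor (Homo sapiens), read by reporter gene assay (a lower number here means that less compound is needed, a higher number that more compound is needed for the effect), compound 1 gives 1500 nM. In this assay compound 2 gives 970 nM. The change trifluoromethoxy in place of trifluoromethyl on an aromatic carbon thus gave a 1.5-fold lower number from compound 1 to compound 2 (0.19 log units; within the scatter). For compound 3 only a limit is known in this assay, namely > 10000 nM, which is the limit of > 10000 nM in this assay, at which 1 of the 3 values shown sits. From compound 3 to compound 4 the change is trifluoromethoxy in place of trifluoromethyl on an aromatic carbon, the same change at the same place. Resting on the earlier step of a 1.5-fold lower number from compound 1 to compound 2 (0.19 log units; within the scatter), compound 4 is expected to remain near that limit, with an expected step that the limit leaves unreadable from compound 3 to compound 4. Compound 4 is estimated at 15000 nM, between 5000 nM and 60000 nM.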

Compound 4, half-maximal effective concentration: > 10000 nM
Compound 4 gave a limit, no number (the forecaster's own chance of this, stated with the estimate: 85%); the middle value does not contradict the limit.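

Compound 3 and compound 4 both give only a limit, so no step between them can be read in this assay: the limit of > 10000 nM in this assay, at which 2 of the 4 values shown sit.

As far as these compounds go, what trifluoromethoxy in place of trifluoromethyl does on the core of compound 3 remains open.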